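A few compounds are considered here, and "the series" means these few. Any claim that something is new, unique, unknown or untested is made for them only; others in the source may bear on it.

Measured in a functional assay on MKN-45 cells (Homo sapiens) for cytotoxicity, read by MTT assay, with a stated time of 72 h; a higher number here means a weaker inhibitor, a lower number a stronger inhibitor:
compound 1 `COc1cc2c(Oc3ccc(NC(=O)c4cc(-c5ccccc5)ccn4)cc3F)ccnc2cc1OCCCN1CCN(C)CC1`: 150 nM
compound 2 `COc1cc2c(Oc3ccc(NC(=O)c4cc(-c5ccc(C(F)(F)F)cc5)ccn4)cc3F)ccnc2cc1OCCCN1CCN(C)CC1`: 330 nM

Going by the values given here, of the two numbers so far, compound 1 holds the lower one; the only measured step, a 2.2-fold higher number from compound 1 to compound 2 (0.34 log units; beyond the scatter), concerns a substituent on the aromatic ring of the amide part and lies beyond the scatter.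

Compound 3 `COc1cc2c(Oc3ccc(NC(=O)c4cc(-c5ccccc5)ccn4)cc3F)ccnc2cc1OCCCN1CCCC1` is the next candidate for this assay. It differs from compound 1 at the other end of the molecule: pyrrolidin-1-yl in place of 4-methylpiperazin-1-yl on a saturated chain carbon, three bonds along the chain from an oxygen on an aromatic ring. Among the compounds with values here, none of the measured steps touches this chain end, so the step from compound 1 to compound 2 gives no direct guidance; it only shows that a single change elsewhere in the molecule moved the number by a modest amount.

With the core and the amide part of compound 1 kept intact, and only the amine on the propyl chain exchanged, compound 3 is expected to give a number close to that of compound 1, the estimated step being a 1.2-fold higher number from compound 1 to compound 3 (0.08 log units; within the scatter). The estimate for compound 3 in this assay is 180 nM, with a range from 70 nM to 500 nM.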

Compound 3, half-maximal inhibitory concentration: 210 nM
Estimate against measurement, compound 3: 1.2-fold (0.07 log units) below, within the range that was stated.
By their numbers in this assay, from the lowest: compounds 1, 3 and 2 (each within the scatter of the next, the first and the last beyond it).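

In this assay, going by these compounds alone, the first look at this chain end gives a 1.4-fold higher number from compound 1 to compound 3 (0.15 log units; within the scatter), so 4-methylpiperazin-1-yl and pyrrolidin-1-yl on the propyl chain cannot be told apart with the shared core and amide part of compound 1 in place. For this one pair, the second ring nitrogen and its methyl group of 4-methylpiperazin-1-yl can therefore be lost without a change beyond the scatter, whereas the trifluoromethyl step on the other end of the molecule, a 2.2-fold higher number from compound 1 to compound 2 (0.34 log units; beyond the scatter), does lie beyond it. No supporting measurement is available that bears on this result or would explain it.

Still open, as far as these compounds go, is whether this tolerance extends to other amines on the propyl chain, such as morpholin-4-yl, piperidin-1-yl or dimethylamino, to a non-basic end group such as a carboxylic acid or a hydroxyl, or to a shorter ethyl or longer butyl chain. Also open, from the compounds shown here alone, is whether pyrrolidin-1-yl behaves the same way when paired with the trifluoromethyl-bearing amide part of compound 2.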